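The source may hold more compounds than are shown below. What is called first, only, known or untested is meant among the compounds shown, and "the series" means these compounds.

Values in a functional assay on MIA PaCa-2 cells (Homo sapiens) for cytotoxicity, read by MTT assay, with a stated time of 72 h; a lower number here means a stronger inhibitor, a higher number a weaker inhibitor:

- compound 1 `COC1=CC(=O)c2c(c(COc3ccc([N+](=O)[O-])cc3F)c(C)n2C)C1=O`: 3560 nM
- compound 2 `COC1=CC(=O)c2c(COc3ccccc3)c(C)n(C)c2C1=O`: 409 nM
- compound 3 `COC1=CC(=O)c2c(COc3ccc(N)cc3)c(C)n(C)c2C1=O`: 160 nM

Compound 3 has the lowest number of the three. The next compound, compound 4 `COC1=CC(=O)c2c(COc3ccc(F)cc3)c(C)n(C)c2C1=O`, has fluoro in place of amino on an aromatic carbon, para to a large group (fluoro in place of amino on an aromatic carbon). Within the data shown here, one measured step bears on this change: a 2.6-fold lower number from compound 2 to compound 3 (0.41 log units; beyond the scatter), with amino in place of hydrogen on an aromatic carbon. Compound 4 has no amino, so its number is expected to rise by a similar modest amount, although fluoro is not hydrogen. The estimated step in this assay is a 2.5-fold higher number from compound 3 to compound 4 (0.40 log units; beyond the scatter). For compound 4 the estimated value is 400 nM, with an expected range of 170 nM to 1000 nM.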

Compound 4, half-maximal inhibitory concentration: 493 nM
The estimate for compound 4 lay 1.2-fold (0.09 log units) below the measured number; low and high end bracket the measured number.
By their numbers in this assay, from the lowest: compound 3; then compounds 2 and 4 (each within the scatter of the next); then compound 1.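

In this assay, fluoro in place of amino gives a 3.1-fold higher number from compound 3 to compound 4 (0.49 log units; beyond the scatter) and so loses the gain seen with amino. Fluoro in place of hydrogen gives a 1.2-fold higher number from compound 2 to compound 4 (0.08 log units; within the scatter) and so makes no difference that can be read, which sets amino apart from both of the other groups at this position. Nothing measured here explains this difference.

Going by these compounds, whether amino is unusual among groups with a nitrogen or oxygen at this position remains open. A methylamino, dimethylamino, hydroxyl or acetamido group could test this.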